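Swapping the Heteroaryl Ring on a Sulfonamide Nitrogen

The source may report more compounds than this note shows. Statements on the series, on what has been measured and on what is new or still open speak of the compounds shown alone.

Two measured compounds share one core and differ only in the ring attached to a sulfonamide nitrogen. For the measured compounds named here, compound 1 `C=C1CC[C@@H]2[C@](C)(COC(C)=O)[C@H](OC(C)=O)CC[C@@]2(C)[C@H]1CC(Nc1ccc(S(=O)(=O)Nc2ccc(Cl)nn2)cc1)C1=CCOC1=O` carries a 6-chloropyridazin-3-yl group there; in a functional assay on SW-620 cells (Homo sapiens) for inhibition, read by sulforhodamine B assay, with a stated time of 48 h (a higher number here means a weaker inhibitor of growth, a lower number a stronger inhibitor of growth), compound 1 gives 2800 nM, which places it at one end of the two numbers, with compound 2 as its only neighbour within the scatter. Compound 2 `C=C1CC[C@@H]2[C@](C)(COC(C)=O)[C@H](OC(C)=O)CC[C@@]2(C)[C@H]1CC(Nc1ccc(S(=O)(=O)Nc2ncccn2)cc1)C1=CCOC1=O` carries a pyrimidin-2-yl group instead, and in this assay compound 2 gives 2250 nM; the step of a 1.2-fold lower number from compound 1 to compound 2 (0.09 log units; within the scatter) is within the scatter. Compound 3 `C=C1CC[C@@H]2[C@](C)(COC(C)=O)[C@H](OC(C)=O)CC[C@@]2(C)[C@H]1CC(Nc1ccc(S(=O)(=O)Nc2nccs2)cc1)C1=CCOC1=O` has not yet been measured and differs from compound 1 by 1,3-thiazol-2-yl in place of 6-chloropyridazin-3-yl on a sulfonamide nitrogen. Going by the values given here, the one measured step that bears on this, a 1.2-fold lower number from compound 1 to compound 2 (0.09 log units; within the scatter), exchanged one aromatic ring on that nitrogen for another and produced nothing beyond the scatter, so the expectation is for a similarly small movement. For compound 3 the expected step is a 1.1-fold lower number from compound 1 to compound 3 (0.05 log units; within the scatter), estimated to stay within the scatter. Compound 3 is therefore estimated at 2500 nM, with a range from 1200 nM to 5500 nM.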

Compound 3, concentration for total growth inhibition: 3980 nM
The estimate for compound 3 lay 1.6-fold (0.20 log units) below the measured number; the measured number falls inside the stated range.
By their numbers in this assay, from the lowest: compounds 2, 1 and 3 (each within the scatter of the next).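

Compound 3 shows that the ring on the sulfonamide nitrogen can go from six-membered to five-membered, and can hold sulfur and no chlorine, while the number in this assay stays within the scatter (a 1.4-fold higher number from compound 1 to compound 3 (0.15 log units; within the scatter); a 1.8-fold higher number from compound 2 to compound 3 (0.25 log units; within the scatter)). All three rings therefore read alike in this assay, so at this position neither the ring size nor the heavy-atom count of the group, across the three rings shown, has yet produced a step beyond the scatter. No measurement shown here offers an explanation for this similarity.

All three groups on this nitrogen are aromatic rings with two hetero atoms. As far as these compounds go, how the number would read with a non-aromatic group there, such as a methyl group, a longer alkyl chain or an amine, remains open.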